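A Ring Hydroxy Added to Two Related Compounds

A few compounds are considered here, and "the series" means these few. Any claim that something is new, unique, unknown or untested is made for them only; others in the source may bear on it.

Compound 1 `Cc1nsc2c1nc(SCc1ccccc1)n2[C@H]1C[C@H](O)[C@@H](CO)O1`: in a functional assay on L1210 cells (Mus musculus) for antiproliferative activity (on this read-out higher numbers stand for weaker inhibition and lower numbers for stronger inhibition), compound 1 gives > 100000 nM, which is a limit of the assay and not a number.
Compound 2 `CSc1nc2sncc2n1[C@H]1C[C@H](O)[C@@H](CO)O1`: in this assay compound 2 gives 20000 nM.
Compound 3 `Cc1nsc2c1nc(SCc1ccccc1)n2[C@@H]1O[C@H](CO)[C@@H](O)[C@@H]1O`: in this assay compound 3 gives > 100000 nM, again a limit of the assay.

Among the measured compounds shown here, compound 2 supplies the only number among the three measured compounds; the other two values are limits, as the limit of > 100000 nM in this assay, at which 2 of the 3 values shown sit, shows. The change from compound 1 to compound 3 is hydroxy in place of hydrogen on a saturated ring carbon, and its step in this assay is a step that the two limits leave unreadable from compound 1 to compound 3, so nothing can be read from that pair. How the core of compound 2 differs from the core of compound 1 is not broken down here.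

Compound 4 `CSc1nc2sncc2n1[C@@H]1O[C@H](CO)[C@@H](O)[C@@H]1O` is not yet measured. It differs from compound 2 by hydroxy in place of hydrogen on a saturated ring carbon, the same change as that from compound 1 to compound 3. Since the measured step for that change is unreadable, the expectation for compound 4 rests on compound 2 alone, with 20000 nM as its anchor, and the step is estimated as a 2.0-fold higher number from compound 2 to compound 4 (0.30 log units; within the scatter). Compound 4 is expected to give about 40000 nM in this assay, estimated between 10000 nM and 100000 nM.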

Compound 4, half-maximal inhibitory concentration: 11000 nM
Compound 4: middle estimate off by 3.6-fold (0.56 log units), on the high side; the range from low to high includes it.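

On the core of compound 2, hydroxy in place of hydrogen on a saturated ring carbon gives a 1.8-fold lower number from compound 2 to compound 4 (0.26 log units; within the scatter) in this assay, so on this core the change cannot be told apart from the ordinary spread of repeated measurements. The same change on the core of compound 1 cannot be read, because compound 1 and compound 3 both stand at a limit of the assay and not at a number: the limit of > 100000 nM in this assay, at which 2 of the 4 values shown sit. The series therefore offers a single readable step on a single core, which shows that the change was tolerated on the core of compound 2 but does not show whether it behaves the same way on the core of compound 1.

The compounds shown leave open whether an amine or a fluorine on that saturated ring carbon would give a clearer step on the core of compound 2. They also leave open what an amine or a carboxylic acid in place of the hydroxymethyl group would do in this assay.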